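This account rests on a few compounds, and the source may have more. Where it says the series, first, only, none or still open, it means among the compounds named here.

In a functional assay on the whole organism for inhibition, with Rattus norvegicus as the target, at a dose of 10 mg/kg by the oral route (a lower number here means less inhibition, a higher number more inhibition at the dose given (going by the name of the read-out)), compound 1 `COc1cccc([C@H]2O[C@H](CC(=O)NCCCCC(=O)O)C(=O)N(CC(C)(C)CO)c3ccc(Cl)cc32)c1OC` gives 50%. Compound 2 `COc1cccc([C@H]2O[C@H](CC(=O)NCCC(=O)O)C(=O)N(CC(C)(C)CO)c3ccc(Cl)cc32)c1OC` gives 19% in this assay, the lower of the two numbers, reached through the step of a number 31 percentage points lower from compound 1 to compound 2 (beyond the scatter). Compound 3 `COc1cccc([C@H]2O[C@H](CC(=O)N3CCC(CCC(=O)O)CC3)C(=O)N(CC(C)(C)CO)c3ccc(Cl)cc32)c1OC` differs from compound 2 in one place: 4-(2-carboxyethyl)piperidin-1-yl in place of (2-carboxyethyl)amino on a carbonyl carbon. Among the compounds with values here, no measured step shows this exact exchange. Within the data shown here, the only step, a number 31 percentage points lower from compound 1 to compound 2 (beyond the scatter), went with a shorter path to the carboxy group and lowered inhibition, so a change that carries the carboxy group back out along a longer path is expected to raise inhibition, by a number 21 percentage points higher from compound 2 to compound 3 (beyond the scatter), though with wide uncertainty. Compound 3 is therefore estimated at 40%, between 15% and 65%.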

Compound 3, a percentage reported as inhibition, in the whole organism at one dose (the size of the read-out at that dose, not a potency): 76%
Compound 3: the middle estimate sits 36 percentage points below what was measured, outside the stated range (above it).
By their numbers in this assay, from the lowest: compound 2; then compound 1; then compound 3.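

Within the data shown here, on the carbonyl carbon, 4-(2-carboxyethyl)piperidin-1-yl gives the highest number so far in this assay, with a number 57 percentage points higher from compound 2 to compound 3 (beyond the scatter) and a number 26 percentage points higher from compound 1 to compound 3 (beyond the scatter). Neither open-chain group shown, (2-carboxyethyl)amino or (4-carboxybutyl)amino, reaches that level, so the longer of the two chains does not match what the six-membered ring version achieves. Nothing available explains this gain.

From the compounds shown here alone, it remains open whether the ring itself or the length of the chain on it matters more. A shorter 4-(carboxymethyl)piperidin-1-yl group or a piperazine ring carrying the same 2-carboxyethyl chain would help separate these.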